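From hydroxy to methyl on an aromatic carbon

The source may report more compounds than this note shows. Statements on the series, on what has been measured and on what is new or still open speak of the compounds shown alone.

Among the measured compounds shown here, only two compounds sharing one core have been measured so far. In a functional assay on HL-60 cells (Homo sapiens) for cytotoxicity, read by WST assay, with a stated time of 48 h (a lower number here means that less compound is needed, a higher number that more compound is needed for the effect), compound 1 (`O=C1OC[C@H](Cc2ccccc2)[C@H]1Cc1ccccc1OC(F)(F)F`) gives 39000 nM as a true number.

Compound 2 (`O=C1OC[C@H](Cc2ccccc2)[C@H]1Cc1cccc(O)c1`) is reported as > 100000 nM and that value is a limit of the assay, not a number.

Compound 3 (`Cc1cccc(C[C@H]2C(=O)OC[C@@H]2Cc2ccccc2)c1`) has not yet been measured. It keeps the core of compound 2 but carries methyl in place of hydroxy on an aromatic carbon, meta to a large group, so that 3-hydroxyphenyl becomes 3-methylphenyl (methyl in place of hydroxy on an aromatic carbon). For the measured compounds named here, no measured pair isolates this swap, so the expectation rests on little. The nearest guide is compound 1 at 39000 nM in this assay where a different group sits on that ring and a number was obtained. A modest move toward lower concentrations is therefore expected, meaning that less compound would be needed: the estimated change is an at least 2.2-fold lower number from compound 2 to compound 3 (0.34 log units; beyond the scatter) and the reading could still end at a limit. Compound 3 is expected at 45000 nM (estimated range 18000 nM to 100000 nM).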

Compound 3, half-maximal effective concentration: 53000 nM
Estimate against measurement, compound 3: 1.2-fold (0.07 log units) below, within the range that was stated.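

This position now carries a group that gives a true number, as in this assay compound 3 gives 53000 nM. With hydroxy in the same place, compound 2 is reported as > 100000 nM, which is a limit of the assay and not a number. Exchanging hydroxy, with its hydrogen-bond donor, for methyl, which has none, therefore reads as an at least 1.8-fold lower number from compound 2 to compound 3 (0.27 log units; that floor lies within the scatter), and the true size of this step stays unknown because one end of it is not a number: the limit of > 100000 nM in this assay, at which 1 of the 3 values shown sits.

This single pair cannot separate the loss of the hydrogen-bond donor from the arrival of a carbon at this position, so it does not tell which part of the exchange goes with the change in reading. An amine, a methoxy group, a chlorine atom or a longer chain such as ethyl in the same place would show how far the reading here depends on the group that sits there.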